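The compounds below may be only part of what the source reports. "The series", "measured", "known", "first", "only" and "open" are said of these compounds alone.

In a functional assay on HCT-15 cells (Homo sapiens) for inhibition, read by MTT assay, with a stated time of 72 h (on this read-out lower numbers stand for stronger inhibition and higher numbers for weaker inhibition), compound 1 `COc1ccc(CNCc2c(OC)cc(Oc3cccc(Nc4ccccc4)c3)cc2OC)cc1` gives 2650 nM, compound 2 `COc1cc(Oc2cccc(Nc3ccccc3)c2)cc(OC)c1CNCc1ccccc1` gives 5020 nM, and compound 3 `COc1ccc(CCCNCc2c(OC)cc(Oc3ccc(Nc4ccccc4)cc3)cc2OC)cc1` gives 2180 nM. Going by the values given here, compound 2 has the highest number of the three; the step of a 1.9-fold higher number from compound 1 to compound 2 (0.28 log units; within the scatter) stays within the scatter, while its gap to compound 3, for which no single-point step is defined, lies beyond the scatter. Compound 4 `COc1cc(Oc2cccc(Nc3ccccc3)c2)cc(OC)c1CNCc1ccc(F)cc1` differs from compound 2 by fluoro in place of hydrogen on an aromatic carbon, sitting para to a large group. Among the compounds with values here, the only measured step that bears on this is the one from compound 1 to compound 2, where removing a methoxy from this same ring left the number within the scatter, a 1.9-fold higher number from compound 1 to compound 2 (0.28 log units; within the scatter). A single fluoro on the same ring is therefore expected to move the number little in this assay, with no direction favoured beyond the scatter. For compound 4 the estimated value is 4000 nM, between 1500 nM and 11000 nM, which means an expected step of a 1.3-fold lower number from compound 2 to compound 4 (0.10 log units; within the scatter).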

Compound 4, half-maximal inhibitory concentration: 3640 nM
The estimate for compound 4 lay 1.1-fold (0.04 log units) above the measured number, and the stated range covers the measured number.
By their numbers in this assay, from the lowest: compounds 3, 1, 4 and 2 (each within the scatter of the next, the first and the last beyond it).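

Going from benzyl to 4-fluorobenzyl, with the fluoro para to a large group, gives a 1.4-fold lower number from compound 2 to compound 4 (0.14 log units; within the scatter) in this assay, so adding this fluoro produces no step that stands clear of the scatter. Going by these compounds alone, the comparison of the two substituents gives a 1.4-fold higher number from compound 1 to compound 4 (0.14 log units; within the scatter), which means that hydrogen, methoxy and fluoro at this place now all lie within the scatter of one another, a point the single step from methoxy to hydrogen could not show. Nothing given here explains why these three groups read alike.

The compounds shown leave open whether a group of a different kind at this place, such as an amine or a carboxylic acid, would move the number beyond the scatter. They also leave open whether a larger halogen such as bromo would do so.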